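The source may report more compounds than this note shows. Statements on the series, on what has been measured and on what is new or still open speak of the compounds shown alone.

Three compounds share one core and differ only in the group attached to the carbonyl carbon. Compound 1, with the structure `CCN(C)C(=O)/C=C1\CCc2c(F)cc(F)cc21`, gives 100% in a functional assay on the whole organism with Mus musculus as the target, at a dose of 100 mg/kg by the intraperitoneal route; on this read-out higher numbers stand for more inhibition at the one dose given (going by the name of the read-out) and lower numbers for less inhibition. Compound 2, the structure `CCNC(=O)/C=C1\CCc2ccc(F)cc21`, gives 100% in this assay. Compound 3, the structure `NC(=O)/C=C1\CCc2c(F)cc(F)cc21`, carries a plain amino group on that carbonyl carbon and gives 100% in this assay, so it stands level with compounds 1 and 2 at the digits shown.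

Going by the values given here, the one single-point step measured so far runs no change at the digits printed from compound 1 to compound 3 (within the scatter), with an amino in place of ethyl(methyl)amino on the carbonyl carbon. Compound 4, with the structure `CCNC(=O)/C=C1\CCc2c(F)cc(F)cc21`, is the next step from compound 3: ethyl in place of hydrogen on an amide-type nitrogen.

That step bears on the measured one, since both only change what sits on the amide-type nitrogen, and that change left the read-out unmoved. A step of no change at the digits printed from compound 3 to compound 4 (within the scatter) is therefore expected, none beyond the scatter. Compound 4 is estimated at 100%, within a range from 88% to 100%.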

Compound 4, a percentage reported as inhibition, in the whole organism at one dose (the size of the read-out at that dose, not a potency): 67%
The estimate for compound 4 lay 33 percentage points above the measured number; the whole stated range lies above it.
By their numbers in this assay, from the lowest: compound 4; then compounds 1, 2 and 3 (each within the scatter of the next).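

In this assay, what sits on the amide-type nitrogen turns out to matter: ethyl in place of hydrogen gives a number 33 percentage points lower from compound 3 to compound 4 (beyond the scatter), although replacing ethyl(methyl)amino with amino had given no change at the digits printed from compound 1 to compound 3 (within the scatter). Two further changes lead to the same compound: hydrogen in place of methyl on that nitrogen gives a number 33 percentage points lower from compound 1 to compound 4 (beyond the scatter), and fluoro in place of hydrogen on an aromatic carbon gives a number 33 percentage points lower from compound 2 to compound 4 (beyond the scatter). Among these four compounds, then, neither ethyl nor the added fluoro goes with the lower number on its own, only the particular combination in compound 4, and nothing available explains the drop.

From the compounds shown here alone, it remains open whether a single methyl or a longer chain such as propyl on that nitrogen would behave like ethyl. Going by these compounds, a ring amine such as pyrrolidine in place of the ethylamino group is equally open.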